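Ring Size at the Chain End in Two Related Series

A few compounds are considered here, and "the series" means these few. Any claim that something is new, unique, unknown or untested is made for them only; others in the source may bear on it.

Measured in a functional assay on HT-29 cells (Homo sapiens) for cytotoxicity, read by MTT assay, with a stated time of 72 h; a lower number here means a stronger inhibitor, a higher number a weaker inhibitor:
Compound 1, `COc1ccc(-c2ccnc(C(=O)Nc3ccc(Oc4ccnc5cc(OCCCN6CCCCC6)c(OC)cc45)c(F)c3)c2)cc1`, gives 690 nM.
Compound 2, `COc1ccc(-c2ccnc(C(=O)Nc3ccc(Oc4ccnc5cc(OCCCN6CCCC6)c(OC)cc45)c(F)c3)c2)cc1`, gives 350 nM.
Compound 3, `COc1cc2c(Oc3ccc(NC(=O)c4nccc(-c5ccccc5)n4)cc3F)ccnc2cc1OCCCN1CCCCC1`, gives 260 nM.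

Compound 2 differs from compound 1 by one change, (pyrrolidin-1-yl in place of piperidin-1-yl on a saturated chain carbon, three bonds along the chain from an oxygen on an aromatic ring), and this change brought a 2.0-fold lower number from compound 1 to compound 2 (0.29 log units; within the scatter). Compound 3 is built on a different core; the difference between the two cores is not broken down here. Compound 4, `COc1cc2c(Oc3ccc(NC(=O)c4nccc(-c5ccccc5)n4)cc3F)ccnc2cc1OCCCN1CCCC1`, has not yet been measured. It differs from compound 3 by pyrrolidin-1-yl in place of piperidin-1-yl on a saturated chain carbon, three bonds along the chain from an oxygen on an aromatic ring, the same change that turned compound 1 into compound 2, at the same place on the chain. A step of similar size is expected, a 1.7-fold lower number from compound 3 to compound 4 (0.24 log units; within the scatter), resting on the earlier step of a 2.0-fold lower number from compound 1 to compound 2 (0.29 log units; within the scatter). In this assay compound 4 is estimated at 150 nM, with the expected range running from 70 nM to 350 nM.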

Compound 4, half-maximal inhibitory concentration: 390 nM
The estimate for compound 4 lay 2.6-fold (0.41 log units) below the measured number; measured number outside the range, above it.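

In this assay, swapping piperidin-1-yl for pyrrolidin-1-yl gave a 1.5-fold higher number from compound 3 to compound 4 (0.18 log units; within the scatter), so the earlier step on the other core did not predict this one. Among these compounds, each core offers only a single pair and each step alone lies within the scatter, so this does not show that pyrrolidin-1-yl helps on one core and harms on the other. What can be said is that the change does not carry over as one fixed step between these two cores: the same change on two cores in this assay, a 2.0-fold lower number (0.29 log units; within the scatter) from compound 1 to compound 2 and a 1.5-fold higher number (0.18 log units; within the scatter) from compound 3 to compound 4, 3.0-fold (0.47 log units) apart, beyond the scatter of two such steps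

The compounds shown leave open how other amines at the end of the chain, such as morpholin-4-yl or dimethylamino, would behave on these two cores. They also leave open whether a longer chain would alter the gap between the two steps.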